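Working notes: compound 3 to compound 4, paw edema

The compounds below may be only part of what the source reports. "The series", "measured", "known", "first", "only" and "open" are said of these compounds alone.

Three measured compounds share one core and differ only in the aryl group on the carbon with a double bond to nitrogen. In a functional assay on the whole organism (strain Wistar) for inhibition, with Rattus norvegicus as the target, read by paw edema, with a stated time of 30 min, at a dose of 10 mg/kg by the intraperitoneal route (a higher number here means more inhibition at the dose given (going by the name of the read-out), a lower number less inhibition), compound 1 `O=C(N/N=C/c1ccccc1)c1cccnc1Nc1cccc(C(F)(F)F)c1` gives 60.4%. Compound 2 `O=C(N/N=C/c1ccc(F)cc1)c1cccnc1Nc1cccc(C(F)(F)F)c1` gives 33.9%, and compound 3 `O=C(N/N=C/c1ccc(O)cc1)c1cccnc1Nc1cccc(C(F)(F)F)c1` gives 59.3%. Compound 3 thus stands second highest of the three numbers; its nearest neighbour is compound 1, where a number 1.1 percentage points lower from compound 1 to compound 3 (within the scatter) falls within the scatter, so no order between the two can be claimed. Against compound 2 the gap is real: a number 25.4 percentage points higher from compound 2 to compound 3 (beyond the scatter).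

Within the data shown here, compound 4 `COc1ccc(/C=N/NC(=O)c2cccnc2Nc2cccc(C(F)(F)F)c2)cc1OC` has not yet been measured in this assay. 3,4-dimethoxyphenyl in place of 4-hydroxyphenyl on a carbon with a double bond to nitrogen The steps that bear on this change are the two that end at compound 3. a number 1.1 percentage points lower from compound 1 to compound 3 (within the scatter) shows that hydroxy in place of hydrogen altered nothing beyond the scatter, while a number 25.4 percentage points higher from compound 2 to compound 3 (beyond the scatter) and a number 26.5 percentage points lower from compound 1 to compound 2 (beyond the scatter) show that fluoro on this ring cost a modest amount. Among the measured compounds shown here, no measured step introduces methoxy at this position, so the size of the step is uncertain; substituent changes on this ring so far ranged from no effect to a modest loss.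

Compound 4 is therefore expected to land roughly level with compound 3 or somewhat lower, estimated at 50% with a range of 30% to 68%, which means an expected step of a number 9.3 percentage points lower from compound 3 to compound 4 (within the scatter).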

Compound 4, a percentage reported as inhibition, in the whole organism at one dose (the size of the read-out at that dose, not a potency): 60.1%
For compound 4 the middle estimate is 10.1 percentage points below the measured one, within the range that was stated.
By their numbers in this assay, from the lowest: compound 2; then compounds 3, 4 and 1 (each within the scatter of the next).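

In this assay the change from 4-hydroxyphenyl to 3,4-dimethoxyphenyl on the carbon with a double bond to nitrogen gives a number 0.8 percentage points higher from compound 3 to compound 4 (within the scatter) and the comparison with the phenyl group gives a number 0.3 percentage points lower from compound 1 to compound 4 (within the scatter) so neither step separates compound 4 from its neighbours. Among these compounds, this position therefore accepts a group of 10 heavy atoms in place of one of 7, and the hydrogen-bond donor of the 4-hydroxyphenyl group is not required to hold the inhibition at this single dose, which the earlier compounds could not show. Among the compounds shown here, the contrast with the 4-fluorophenyl group is a number 26.2 percentage points higher from compound 2 to compound 4 (beyond the scatter) and this leaves compound 2 as the only compound in this set of four that falls away, so the loss cannot be read as a general cost of substituting this ring.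

No data given here account for the separate behaviour of compound 2. On these data alone, it remains open whether a basic amine such as dimethylamino or a carboxylic acid on this ring would hold the read-out at the level of compounds 1, 3 and 4, and whether a chloro or bromo group would follow compound 2.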